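Imide ring contraction in a 5-HT7 arylpiperazine series

A few compounds are considered here, and "the series" means these few. Any claim that something is new, unique, unknown or untested is made for them only; others in the source may bear on it.

Measured compounds:
compound 1 `CC1(C)CC(=O)N(CCCCN2CCN(c3cccc(C(F)(F)F)c3)CC2)C(=O)C1` — 46 nM
compound 2 `CC1(C)CC(=O)N(C2CCC(N3CCN(c4cccc(C(F)(F)F)c4)CC3)CC2)C(=O)C1` — 221 nM

Two compounds have been characterised in an assay on HEK293 cells for displacement of a labelled ligand from 5-hydroxytryptamine receptor 7 (Homo sapiens); on this read-out higher numbers stand for weaker inhibition and lower numbers for stronger inhibition. Compound 1 has the lower number of the two; compound 2 sits higher, and that gap lies beyond the usual scatter. Compound 3 `CC1C(=O)N(CCCCN2CCN(c3cccc(C(F)(F)F)c3)CC2)C(=O)C1C` has not yet been measured. It differs from compound 1 in one place: 3,4-dimethyl-2,5-dioxopyrrolidin-1-yl in place of 4,4-dimethyl-2,6-dioxopiperidin-1-yl on a saturated chain carbon, four bonds along the chain from an amine nitrogen in a ring. Going by the values given here, no step between measured compounds describes such a ring contraction, so the expectation rests on the size of the change alone, which leaves the arylpiperazine, the butyl chain and the two carbonyls in place. The step from compound 1 to compound 3 is expected to be small, within or only slightly beyond the scatter, in either direction: a 1.5-fold higher number from compound 1 to compound 3 (0.18 log units; within the scatter). Compound 3 is accordingly estimated at 70 nM, with a plausible range from 25 nM to 200 nM.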

Compound 3, inhibition constant: 107 nM
For compound 3 the middle estimate is 1.5-fold (0.18 log units) below the measured one, and the stated range covers the measured number.
By their numbers in this assay, from the lowest: compound 1; then compound 3; then compound 2.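

In this assay, the group on the saturated chain carbon, four bonds along the chain from an amine nitrogen in a ring, proves sensitive to a change that leaves the rest of the molecule intact: 3,4-dimethyl-2,5-dioxopyrrolidin-1-yl in place of 4,4-dimethyl-2,6-dioxopiperidin-1-yl gives a 2.3-fold higher number from compound 1 to compound 3 (0.37 log units; beyond the scatter). The ring shrinks from six-membered to five-membered and the methyl groups change position in the same step, while the two carbonyls remain, so this pair cannot separate the two changes. Nothing available accounts for the loss in inhibition.

From the compounds shown here alone, whether a 2,5-dioxopyrrolidin-1-yl group carrying no methyl groups, or a 3,3-dimethyl-2,5-dioxopyrrolidin-1-yl group, would tell ring size from methyl placement remains open. Going by these compounds, it is also open whether the step would hold on a propyl or pentyl chain.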